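The source may report more compounds than this note shows. Statements on the series, on what has been measured and on what is new or still open speak of the compounds shown alone.

The account opens with compound 1 `Cc1cc(-c2noc(C(F)(F)F)n2)cc(C)c1OCCCc1cc(C(N)=O)no1`, and in an ADME assay on HeLa cells (Homo sapiens) for cytotoxicity, read by crystal violet staining, with a stated time of 72 h (on this read-out higher numbers stand for lower toxicity in this test and lower numbers for higher toxicity in this test), compound 1 gives > 100000 nM as a limit of the assay and not a number. Compound 2 `CCNC(=O)c1cc(CCCOc2c(C)cc(-c3noc(C(F)(F)F)n3)cc2C)on1` gives > 100000 nM in this assay and this too is only a limit. The evidence so far is the limit of > 100000 nM in this assay, at which 2 of the 2 values shown sit, and no finer reading exists for compound 2.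

Compound 3 `Cc1cc(-c2noc(C(F)(F)F)n2)cc(C)c1OCCCc1cc(C(=O)NCc2ccccc2)no1` has not yet been measured. Its structure differs from that of compound 2 by phenyl in place of methyl on a saturated chain carbon bound to an amide-type nitrogen and in words this is phenyl in place of methyl on a saturated chain carbon bound to an amide-type nitrogen, so that ethylcarbamoyl becomes benzylcarbamoyl.

For the measured compounds named here, one measured step bears on this nitrogen, namely a step that the two limits leave unreadable from compound 1 to compound 2 and it supplies no size to carry forward. For a number no higher from compound 2 to compound 3 (the limit leaves the size open) the expected change in this assay is therefore none beyond the scatter, and no direction is expected. Compound 3 is estimated at 100000 nM with an expected range from 40000 nM to 200000 nM and the assay may well report only a limit again.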

Compound 3, half-maximal cytotoxic concentration: > 100000 nM
Compound 3: no number, only a limit; the forecaster's own chance of this, stated with the estimate: 75%; the middle value lies on the limit itself.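

In this assay compound 3 gives > 100000 nM, again a limit of the assay and not a number. No step among compound 1, compound 2 and compound 3 can be read: the limit of > 100000 nM in this assay, at which 3 of the 3 values shown sit.

The compounds shown leave open whether ethyl or benzyl on the amide-type nitrogen changes the half-maximal cytotoxic concentration at all.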